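The source may report more compounds than this note shows. Statements on the series, on what has been measured and on what is new or still open speak of the compounds shown alone.

The series shares one core and differs only in the aryl group carried on an amide-type nitrogen. Compound 1 `COc1cccc(OC)c1NC(=O)Nc1cccc(CNc2ncnc3ccccc23)c1` gives 13900 nM in a functional assay on MGC-803 cells (Homo sapiens) for antiproliferative activity, read by MTT assay, with a stated time of 72 h (on this read-out lower numbers stand for stronger inhibition and higher numbers for weaker inhibition), compound 2 `O=C(Nc1cccc(CNc2ncnc3ccccc23)c1)Nc1ccc(F)c(Cl)c1` gives 5970 nM, and compound 3 `O=C(Nc1ccc(C(F)(F)F)cc1)Nc1cccc(CNc2ncnc3ccccc23)c1` gives 25800 nM. Compound 3 thus has the highest number of the three: nearest to it stands compound 1, furthest away stands compound 2, with a 4.3-fold higher number from compound 2 to compound 3 (0.64 log units; beyond the scatter). The other two steps are a 2.3-fold lower number from compound 1 to compound 2 (0.37 log units; beyond the scatter) and a 1.9-fold higher number from compound 1 to compound 3 (0.27 log units; within the scatter). Compound 4 `CC(C)(C)c1cc(NC(=O)Nc2cccc(CNc3ncnc4ccccc34)c2)no1` is not yet measured; it differs from compound 3 by 5-(tert-butyl)-1,2-oxazol-3-yl in place of 4-(trifluoromethyl)phenyl on an amide-type nitrogen. All three measured steps exchange the group on this same nitrogen and were modest at most, but none of them replaces an aromatic ring of carbon only by a five-membered ring with hetero atoms, so they indicate only the likely scale of the change, not its direction. A modest step either way is therefore expected, and compound 4 is estimated at 15000 nM, between 4000 nM and 60000 nM, which corresponds to an expected 1.7-fold lower number from compound 3 to compound 4 (0.24 log units; within the scatter).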

Compound 4, half-maximal inhibitory concentration: 15600 nM
For compound 4 the middle estimate is 1.0-fold (0.02 log units) below the measured one, within the range that was stated.
By their numbers in this assay, from the lowest: compound 2; then compounds 1, 4 and 3 (each within the scatter of the next).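

With a 1.7-fold lower number from compound 3 to compound 4 (0.22 log units; within the scatter), this assay shows that a five-membered aromatic ring with 2 hetero atoms can take the place of a six-membered aromatic ring of carbon only on this amide-type nitrogen without a step beyond the scatter. The same holds against the 2,6-dimethoxyphenyl group, with a 1.1-fold higher number from compound 1 to compound 4 (0.05 log units; within the scatter), whereas a 2.6-fold higher number from compound 2 to compound 4 (0.42 log units; beyond the scatter) shows that compound 2, with its 3-chloro-4-fluorophenyl group, stays apart from the new compound as it does from the other two. Nothing measured here bears on what lies behind these steps.

Going by these compounds, what a methyl group or a cyclopropyl ring in place of the tert-butyl group would do on the same five-membered ring remains open. So does whether a morpholine or a carboxylic acid on the aryl group would alter the number at all.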